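The source may report more compounds than this note shows. Statements on the series, on what has been measured and on what is new or still open speak of the compounds shown alone.

Three compounds sharing one core were tested in a functional assay on the whole organism (strain Wistar) for inhibition, with Rattus norvegicus as the target, read by paw edema, with stated times of 60 min and 4 h, at a dose of 100 mg/kg by the oral route; a lower number here means less inhibition, a higher number more inhibition at the dose given (going by the name of the read-out):

compound 1 `COc1cc2c(cc1OC)C(CC(=O)NC(C)(C)C)CC2` gives 32.8%
compound 2 `COc1cc2c(cc1OC)C(CC(=O)NC1CCCCC1)CC2` gives 50%
compound 3 `COc1cc2c(cc1OC)C(CC(=O)NCc1ccccc1)CC2` gives 18.8%

Compound 3 stands lowest of the three. Its nearest neighbour is compound 1, and the step of a number 14 percentage points lower from compound 1 to compound 3 (beyond the scatter) is beyond the scatter; the step of a number 31.2 percentage points lower from compound 2 to compound 3 (beyond the scatter) is larger still. Between the other two, the step of a number 17.2 percentage points higher from compound 1 to compound 2 (beyond the scatter) shows that the group on the amide-type nitrogen alone moves the read-out by a modest amount in this series.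

Compound 4 `COc1cc2c(cc1OC)C(CC(=O)N1CCOCC1)CC2` is the next compound to be measured. It differs from compound 3 in one place: morpholin-4-yl in place of benzylamino on a carbonyl carbon. Going by the values given here, none of the measured steps exchanges benzylamino for morpholin-4-yl, and none removes the hydrogen-bond donor from the amide; the three measured steps only swap one substituent on the amide-type nitrogen for another. They do show that every change at this position shifted the read-out beyond the scatter, with the benzyl compound lowest. On that basis a modest upward step a number 11.2 percentage points higher from compound 3 to compound 4 (beyond the scatter) is expected, though a change within the scatter cannot be excluded. Compound 4 is estimated at 30%, with a range from 10% to 50%.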

Compound 4, a percentage reported as inhibition, in the whole organism at one dose (the size of the read-out at that dose, not a potency): 13.3%
Compound 4: middle estimate off by 16.7 percentage points, on the high side; low and high end bracket the measured number.
By their numbers in this assay, from the lowest: compounds 4 and 3 (each within the scatter of the next); then compound 1; then compound 2.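

The exchange of benzylamino for morpholin-4-yl on a carbonyl carbon comes out in this assay as a number 5.5 percentage points lower from compound 3 to compound 4 (within the scatter) and so does not separate compound 3 from compound 4, even though the amide hydrogen is gone in compound 4 and a ring with two hetero atoms has entered. The amide hydrogen alone therefore does not decide the read-out at this position: compound 3 keeps it and compound 4 lacks it, yet the two cannot be told apart, while the other two amides stand clear of compound 4, with a number 36.7 percentage points lower from compound 2 to compound 4 (beyond the scatter) and with a number 19.5 percentage points lower from compound 1 to compound 4 (beyond the scatter) as the exchange for morpholin-4-yl. No measurement at hand accounts for these differences.

The compounds shown leave open whether the ring oxygen of morpholin-4-yl or the missing amide hydrogen matters more, which piperidin-1-yl or a cyclohexyl(methyl)amino group on the same carbonyl carbon would help to separate. They also leave open how a carboxylic acid in place of the amide, or a longer chain leading to the carbonyl, would read in this test.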